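Truncating the amino substituent: from hydroxycyclohexyl to methyl

This account rests on a few compounds, and the source may have more. Where it says the series, first, only, none or still open, it means among the compounds named here.

Compound 3 `O[C@H]1CCCC[C@@H]1Nc1nc(-c2ccccc2)nc2c1nnn2Cc1ccccc1` is a ring-bearing amine on the shared core. Among the measured compounds shown here, in an assay on isolated protein for binding affinity to adenosine receptor A1 (Bos taurus) (on this read-out higher numbers stand for weaker inhibition and lower numbers for stronger inhibition), compound 3 gives 10300000 nM, which is the highest of the three numbers so far; compound 1 `FC(F)(F)c1ccccc1Cn1nnc2c(NC3CCCCC3)nc(-c3ccccc3)nc21` gives 6800000 nM and compound 2 `CCCCNc1nc(-c2ccccc2)nc2c1nnn2Cc1ccccc1C(F)(F)F` gives 6500000 nM, both within the scatter of compound 3, so no order can be drawn among the three. Compound 4 `CNc1nc(-c2ccccc2)nc2c1nnn2Cc1ccccc1` carries the change (methyl in place of 2-hydroxycyclohexyl on a nitrogen on an aromatic ring). For the measured compounds named here, the only measured step on this nitrogen, a 1.0-fold lower number from compound 1 to compound 2 (0.02 log units; within the scatter), swaps one amine substituent of similar size for another and shows nothing beyond the scatter; it says little about cutting the substituent down to methyl and losing the hydroxyl. Nothing measured bears on the hydroxyl itself. Given that compounds 1, 2 and 3 sit together, the expectation for compound 4 is a step of a 1.3-fold higher number from compound 3 to compound 4 (0.10 log units; within the scatter) of no clear direction, with the weak end of the range left open. Compound 4 is therefore estimated at 13000000 nM in this assay, between 4000000 nM and 45000000 nM.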

Compound 4, inhibition constant: 353000000 nM
Compound 4: middle estimate off by 27-fold (1.43 log units), on the low side; the measured number lies above the stated range.
By their numbers in this assay, from the lowest: compounds 2, 1 and 3 (each within the scatter of the next); then compound 4.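

In this assay, among the compounds shown here, methyl in place of 2-hydroxycyclohexyl on a nitrogen on an aromatic ring gives a 34-fold higher number from compound 3 to compound 4 (1.53 log units; beyond the scatter) and is the first step beyond the scatter. The only earlier step on this nitrogen, a 1.0-fold lower number from compound 1 to compound 2 (0.02 log units; within the scatter) for butyl in place of cyclohexyl, had shown no effect of the substituent. This amine position is therefore not indifferent to its substituent: the two earlier substituents left the numbers within the scatter, whereas this change to methyl does not.

The step removes the hydroxyl and the six-membered ring together, so the compounds shown cannot assign it to either, and a 2-hydroxyethyl or propyl chain on the core of compound 4 would help separate the two. No evidence is available to explain the step.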